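The source may report more compounds than this note shows. Statements on the series, on what has been measured and on what is new or still open speak of the compounds shown alone.

Measured in an ADME assay on MDCK cells (Canis lupus familiaris) for permeability, in the apical to basolateral direction; a lower number here means that the compound crosses the layer more slowly, a higher number that the compound crosses the layer faster:

Compound 1 `CC[S+]([O-])(=NC)c1ccc(Nc2ncc(C(F)(F)F)c(N[C@@H]3CCC[C@H]3N(C)C)n2)cc1`: 7.8 10^-6 cm/s
Compound 2 `CC(C)N=[S+](C)([O-])c1ccc(Nc2ncc(C(F)(F)F)c(N[C@@H]3CCC[C@H]3N(C)C)n2)cc1`: 6.6 10^-6 cm/s

Only these two compounds have been measured so far, and compound 2 lies within the scatter of compound 1. The next compound to be tested is compound 3 `CN(C)[C@@H]1CCC[C@H]1Nc1nc(Nc2ccc([S+](C)(=N)[O-])cc2)ncc1C(F)(F)F`. It differs from compound 2 as follows: hydrogen in place of isopropyl on a double-bonded nitrogen. In words, this is hydrogen in place of isopropyl on a double-bonded nitrogen.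

Just one measured step bears on this, and only loosely: a 1.2-fold lower number from compound 1 to compound 2 (0.07 log units; within the scatter). That step also altered the group on the aromatic carbon, yet both of its compounds keep a carbon group on the double-bonded nitrogen, which compound 3 does not. Among the measured compounds shown here, no measured compound carries hydrogen there, so the data give no direct guide to direction. A modest move towards a lower number in this assay is expected, though one not clearly beyond the scatter, and with little confidence. The estimate amounts to an expected 1.5-fold lower number from compound 2 to compound 3 (0.17 log units; within the scatter). For compound 3 the estimated value is 4.5 10^-6 cm/s, with an expected range of 1.8 10^-6 cm/s to 9 10^-6 cm/s.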

Compound 3, apparent permeability: 1 10^-6 cm/s
For compound 3 the middle estimate is 4.5-fold (0.65 log units) above the measured one; the whole stated range lies above it.
By their numbers in this assay, from the lowest: compound 3; then compounds 2 and 1 (each within the scatter of the next).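

In this assay the double-bonded nitrogen proves to be a sensitive place: hydrogen in place of isopropyl gives a 6.6-fold lower number from compound 2 to compound 3 (0.82 log units; beyond the scatter). By contrast, compound 1 and compound 2, which both keep a carbon group on that nitrogen, lie within the scatter of each other. Among the compounds shown here, the step that changes the whole group on the aromatic carbon, and so also removes the carbon group from that nitrogen, gives a 7.8-fold lower number from compound 1 to compound 3 (0.89 log units; beyond the scatter) and is of similar size, which leaves compound 3, the only compound with hydrogen there, standing apart from the other two. Nothing in the information available accounts for this difference.

The compounds shown leave open whether hydrogen alone sets compound 3 apart or whether any carbon group on this nitrogen would serve equally, since compound 1 carries a smaller carbon group there than compound 2 but also differs from it in the other group on sulfur. From the compounds shown here alone, how an acetyl group, a cyclopropyl ring or a longer chain on the same nitrogen would fall relative to hydrogen and isopropyl also remains open.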